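Inverting One Ring Stereocentre in a Cyclitol Series

This account rests on a few compounds, and the source may have more. Where it says the series, first, only, none or still open, it means among the compounds named here.

Measured so far:
compound 1 `N[C@H]1[C@@H](O)[C@H](O)[C@H](O)[C@@H](O)[C@H]1O` — 19%
compound 2 `O[C@@H]1[C@@H](O)[C@@H](O)[C@@H](S)[C@@H](O)[C@@H]1O` — 40%
compound 3 `O[C@@H]1[C@@H](O)[C@H](O)[C@@H](F)[C@@H](O)[C@H]1O` — 37%

Of the compounds shown here, three have been tested in an assay for inhibition of CDP-diacylglycerol--inositol 3-phosphatidyltransferase (Mus musculus), tested at 5 mM; a higher number here means more inhibition at the concentration tested (going by the name of the read-out), a lower number less inhibition. Compound 1 `N[C@H]1[C@@H](O)[C@H](O)[C@H](O)[C@@H](O)[C@H]1O` gives 19%. For the measured compounds named here, compound 2 `O[C@@H]1[C@@H](O)[C@@H](O)[C@@H](S)[C@@H](O)[C@@H]1O` gives 40%, and the only single-point step among the measured compounds, a number 21 percentage points higher from compound 1 to compound 2 (beyond the scatter), comes from a sulfanyl in place of amino on a saturated ring carbon. Compound 3 `O[C@@H]1[C@@H](O)[C@H](O)[C@@H](F)[C@@H](O)[C@H]1O` gives 37%; it stands second highest of the three, close to compound 2, and clearly higher than compound 1.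

Compound 4 `O[C@@H]1[C@H](F)[C@@H](O)[C@@H](O)[C@H](O)[C@@H]1O` is the next compound to be measured. It differs from compound 3 only as follows: the two compounds have the same atoms and bonds and differ only in configuration as drawn: 1 of 6 stereo elements differ; a stereocentre at a saturated ring carbon is drawn R in compound 3 and S in compound 4. Going by the values given here, no measured step in this set concerns a change of configuration alone; the one step recorded, from amino to sulfanyl, exchanges atoms and does not bear on an inversion at a ring carbon. With nothing to guide a direction, the expectation for the step of a number 1 percentage points lower from compound 3 to compound 4 (within the scatter) is that it stays within the usual scatter of the read-out. Compound 4 is therefore estimated to give about 36%, within a range from 18% to 54%.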

Compound 4, a percentage reported as inhibition, at one concentration (the size of the read-out at that concentration, not a potency): 22%
The estimate for compound 4 lay 14 percentage points above the measured number, within the range that was stated.
By their numbers in this assay, from the lowest: compounds 1 and 4 (each within the scatter of the next); then compounds 3 and 2 (each within the scatter of the next).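

In this assay, for the compounds shown here, the new result is a number 15 percentage points lower from compound 3 to compound 4 (beyond the scatter), and it is the first step that concerns configuration alone. The earlier step from amino to sulfanyl exchanged atoms and so could not separate the identity of a group from its orientation, whereas here nothing leaves and nothing enters, and a single inverted stereocentre at a saturated ring carbon is enough to move the read-out beyond the scatter. The step can be assigned to the inversion itself, and to no exchange of groups, because of one structural fact: the fact that compounds 3 and 4 differ only in the configuration as drawn.

From the compounds shown here alone, whether this sensitivity belongs to this stereocentre alone remains open, as does whether inverting any of the other stereo elements of the shared core would lower the number, raise it or leave it unchanged. Going by these compounds alone, it is equally unknown whether the same inversion would have a similar effect with a group other than fluorine on the core, such as a chlorine atom or a methoxy group, or with the amino and sulfanyl groups of the earlier compounds.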